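A few compounds are considered here, and "the series" means these few. Any claim that something is new, unique, unknown or untested is made for them only; others in the source may bear on it.

Of the compounds shown here, three built on one shared core have been tested for cytotoxicity. Compound 1 `COc1cc(-c2cc(/C=C/C(=O)c3ccc(N)cc3)[nH]n2)cc(OC)c1OC` carries a 4-aminophenyl on its carbonyl carbon; in a functional assay on TK-10 cells (Homo sapiens) for cytotoxicity, read by sulforhodamine B assay, with a stated time of 48 h, tested at 10 uM (on this read-out lower numbers stand for a stronger effect and higher numbers for a weaker effect at the one concentration tested), compound 1 gives 26%. Compound 2 `COc1cc(-c2cc(/C=C/C(=O)c3ccc(Cl)c(Cl)c3)[nH]n2)cc(OC)c1OC` carries a 3,4-dichlorophenyl in that place, and in this assay compound 2 gives 46%. Compound 3 `COc1ccc(-c2cc(/C=C/C(=O)c3cc(OC)c(OC)c(OC)c3)[nH]n2)cc1OC` differs in more than one place, and in this assay compound 3 gives 7%.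

Compound 2 therefore stands highest of the three numbers, meaning the weakest effect in this assay, with compound 1 nearest and compound 3 furthest, both gaps beyond the usual scatter. Going by the values given here, the single clean step recorded so far is a number 20 percentage points higher from compound 1 to compound 2 (beyond the scatter), where 3,4-dichlorophenyl replaced 4-aminophenyl on the carbonyl carbon.

Compound 4 `COc1ccc(C(=O)/C=C/c2cc(-c3cc(OC)c(OC)c(OC)c3)n[nH]2)cc1` is the next one to be measured. It differs from compound 2 by 4-methoxyphenyl in place of 3,4-dichlorophenyl on a carbonyl carbon. The step from compound 1 to compound 2 is the only one that bears on this change, since it also swaps the ring on the carbonyl carbon, and it moved the number upward on reaching 3,4-dichlorophenyl. Leaving 3,4-dichlorophenyl for a ring that carries one hydrogen-bond acceptor is expected to move the number back downward by a modest amount, a number 16 percentage points lower from compound 2 to compound 4 (beyond the scatter). Compound 4 is thus expected to give about 30%, somewhere between 15% and 50%.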

Compound 4, a percentage reported as activity, at one concentration (the size of the read-out at that concentration, not a potency): -29%
For compound 4 the middle estimate is 59 percentage points above the measured one; the measured number lies below the stated range.
By their numbers in this assay, from the lowest: compound 4; then compound 3; then compound 1; then compound 2.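

In this assay the ring on the carbonyl carbon proves able to produce a large change, not just the modest one seen so far: 4-methoxyphenyl in place of 3,4-dichlorophenyl gives a number 75 percentage points lower from compound 2 to compound 4 (beyond the scatter) on that carbon. The exchange of a single group on this ring matters as well, since methoxy in place of amino on an aromatic carbon gives a number 55 percentage points lower from compound 1 to compound 4 (beyond the scatter) and shows that 4-aminophenyl and 4-methoxyphenyl are far from interchangeable here. Among the three rings compared at this place, 4-methoxyphenyl therefore gives the lowest number and the strongest effect, with compound 4 at -29% and both of its steps beyond the scatter. Nothing shown accounts for the size of these steps.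

As far as these compounds go, it remains open whether the large step depends on the oxygen of the methoxy group specifically, which a hydroxy or an ethoxy group on the same ring could test. From the compounds shown here alone, it is equally open how a carboxylic acid or a dimethylamino group on that ring would read, and so whether 4-methoxyphenyl marks a limit at this place or only one point along a wider range.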